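Amide substitution on the shared core, next step

A few compounds are considered here, and "the series" means these few. Any claim that something is new, unique, unknown or untested is made for them only; others in the source may bear on it.

Compound 1 `COc1ccccc1N1CCN(CCCNc2ncccc2C(=O)NC(C)(C)C)CC1` and compound 2 `CNC(=O)c1cccnc1NCCCN1CCN(c2ccccc2OC)CC1` share one core and differ only at the amide nitrogen. In a functional assay for antagonist activity at Alpha-1A adrenergic receptor (Oryctolagus cuniculus) (a lower number here means tighter binding, a higher number weaker binding), compound 1 gives 1.26 nM, and compound 2 gives 1 nM. The two numbers sit within the scatter of each other, as the step of a 1.3-fold lower number from compound 1 to compound 2 (0.10 log units; within the scatter) shows, so compound 2 stands together with compound 1 at the low end of the two values shown.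

Compound 3 `COc1ccccc1N1CCN(CCCNc2ncccc2C(=O)N(C)C)CC1` carries the change (methyl in place of hydrogen on an amide-type nitrogen). For the measured compounds named here, the one measured step, from compound 1 to compound 2, bears on it only in that it also alters the substituent on that nitrogen, and it stayed within the scatter. Going by the values given here, no measured compound lacks the amide hydrogen, so the data carry no information on that part of the change. For compound 3 the expected step is a 2.5-fold higher number from compound 2 to compound 3 (0.40 log units; beyond the scatter), a small weakening at most. Compound 3 is therefore estimated at 2.5 nM, with a range of 0.7 nM to 9 nM.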

Compound 3, dissociation constant: 1.59 nM
Beside the measured number, compound 3's estimate is 1.6-fold (0.20 log units) above it; measured number inside the range.
By their numbers in this assay, from the lowest: compounds 2, 1 and 3 (each within the scatter of the next).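

Methyl in place of the amide hydrogen reads in this assay as a 1.6-fold higher number from compound 2 to compound 3 (0.20 log units; within the scatter) and gives the first comparison at this position with no hydrogen on the amide-type nitrogen; compounds with and without that hydrogen cannot be told apart here. Dimethylamino in place of (tert-butyl)amino on the carbonyl carbon reads as a 1.3-fold higher number from compound 1 to compound 3 (0.10 log units; within the scatter) and places the dimethylamide together with the tert-butyl and methyl amides, so the three substituent patterns on this nitrogen give no separable values. No evidence at hand bears on the reason for this result.

The compounds shown leave open whether this insensitivity extends beyond simple alkyl groups on the nitrogen. The unsubstituted carboxamide, a phenyl group on the nitrogen and a carboxylic acid in place of the amide would each test that limit.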